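The compounds below may be only part of what the source reports. "The series", "measured", "known", "first", "only" and "open" are said of these compounds alone.

In an assay on BTI cells for inhibition of Amine oxidase [flavin-containing] B (Homo sapiens), read by fluorescence, with stated times of 30 min and 1 h (on this read-out higher numbers stand for weaker inhibition and lower numbers for stronger inhibition), compound 2 `C[C@H](NCc1ccc(OCCCCN2CCN(c3cccc4c3ccn4Cc3cccc(Cl)c3)CC2)cc1)C(N)=O` gives only a limit, > 1000 nM. Compound 1 `C#CCNC1CCc2c(OCCCN3CCN(c4cccc5c4ccn5Cc4cccc(Cl)c4)CC3)cccc21`, which also carries a propargyl group, gives in this assay likewise a limit, > 1000 nM. Compound 3 `C[C@H](NCc1ccc(OCCCCN2CCN(c3cccc4c3ccn4S(=O)(=O)c3ccccc3)CC2)cc1)C(N)=O` gives in this assay a limit as well, > 1000 nM. All three values stand at the same boundary, (the limit of > 1000 nM in this assay, at which 3 of the 3 values shown sit), so a step that the two limits leave unreadable from compound 2 to compound 3 cannot be read. Compound 4 `C#CCN(C)Cc1ccc(OCCCCN2CCN(c3cccc4c3ccn4Cc3cccc(Cl)c3)CC2)cc1` differs from compound 2 by methyl(propargyl)amino in place of (1-carbamoylethyl)amino on a saturated chain carbon bound to an aromatic carbon. Among the measured compounds shown here, no measured step bears on this change, and the propargyl-bearing compound 1 shows no sign of inhibition within reach of this assay. Compound 4 is therefore expected to remain weak, with a step that the limit leaves unreadable from compound 2 to compound 4 that is a guess rather than a reading. The estimate for compound 4 is 1500 nM, within 150 nM to 10000 nM.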

Compound 4, half-maximal inhibitory concentration: 323 nM
Estimate against measurement, compound 4: 4.6-fold (0.67 log units) above; the range from low to high includes it.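

In this assay, methyl(propargyl)amino in place of (1-carbamoylethyl)amino on a saturated chain carbon bound to an aromatic carbon gives an at least 3.0-fold lower number from compound 2 to compound 4 (0.49 log units; beyond the scatter). Among the compounds shown here, this is the only readable step in the set, and it shows that this position can move the read-out. Its full size stays open, as compound 2 gives only a limit: the limit of > 1000 nM in this assay, at which 3 of the 4 values shown sit.

From the compounds shown here alone, it remains open whether the propargyl group itself matters, which a dimethylamino or methyl(propyl)amino group at this place would test. Also open, going by these compounds, is what phenylsulfonyl in place of 3-chlorobenzyl on an aromatic nitrogen would do in compound 4.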